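A few compounds are considered here, and "the series" means these few. Any claim that something is new, unique, unknown or untested is made for them only; others in the source may bear on it.

Measured so far in a functional assay (Cavia porcellus) with sulfonylurea receptors; K-ATP channels (Homo sapiens) as the target; on this read-out higher numbers stand for weaker inhibition and lower numbers for stronger inhibition:
compound 1 `COc1cccc(S(=O)(=O)c2ccc(NC(=O)C(C)(O)C(F)(F)F)cc2)c1` gives 16000 nM.
compound 2 `Cc1ccccc1S(=O)(=O)c1ccc(NC(=O)C(C)(O)C(F)(F)F)cc1` gives 5100 nM.
compound 3 `CC(O)(C(=O)Nc1ccc(S(=O)(=O)c2ccc(Br)cc2)cc1)C(F)(F)F` gives only a limit, > 30000 nM.

Compound 1 holds the highest of the two numbers in this assay. For compound 3 the assay reports a limit of > 30000 nM in this assay, at which 1 of the 3 values shown sits, and no number. The steps run as follows: a 3.1-fold lower number from compound 1 to compound 2 (0.50 log units; beyond the scatter); an at least 1.8-fold higher number from compound 1 to compound 3 (0.27 log units; that floor lies within the scatter); an at least 5.8-fold higher number from compound 2 to compound 3 (0.76 log units; beyond the scatter).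

Compound 4 `CC(O)(C(=O)Nc1ccc(S(=O)(=O)c2cccc(C(F)(F)F)c2)cc1)C(F)(F)F` differs from compound 1 by trifluoromethyl in place of methoxy on an aromatic carbon. Within the data shown here, none of the measured steps exchanges a group of this kind, so they bear on it only indirectly: a methyl-bearing ring lies below compound 1 and a bromo-bearing ring at the limit above it. For compound 4 no step beyond the scatter is expected in either direction, and a limit remains possible. Compound 4 is estimated at 16000 nM, range 5000 nM to 40000 nM, which means an expected step of no change at the digits printed from compound 1 to compound 4 (within the scatter).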

Compound 4, half-maximal inhibitory concentration: > 30000 nM
Compound 4 was reported as a limit; the forecaster's own chance of this, stated with the estimate: 30%; middle value at least 1.8-fold (0.27 log units) from the limit.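

In this assay, trifluoromethyl in place of methoxy gives an at least 1.8-fold higher number from compound 1 to compound 4 (0.27 log units; that floor lies within the scatter), so no gain in inhibition is seen, and whether inhibition is weakened at all cannot be read. Compound 4 gives a limit and not a number, as compound 3 does: the limit of > 30000 nM in this assay, at which 2 of the 4 values shown sit. Among these compounds, at this place, meta to a large group, methoxy is so far the only group that returns a number.

Going by these compounds, whether an amine or a carboxylic acid at this place would return a number remains open. On these data alone, the actual value of compound 4 also remains open.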